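Hydroxy in place of hydrogen on compound 1

A few compounds are considered here, and "the series" means these few. Any claim that something is new, unique, unknown or untested is made for them only; others in the source may bear on it.

Compound 1 `c1ccc(Nc2nccc(-c3ccncc3)n2)cc1` stands second highest of the three numbers in a functional assay for inhibition, with Homo sapiens as the target (a higher number here means a weaker inhibitor, a lower number a stronger inhibitor), where compound 1 gives 900 nM. Compound 2 `CC(=O)Nc1cccc(Nc2nccc(-c3ccncc3)n2)c1` gives 2700 nM, and compound 3 `c1cc(Nc2nccc(-c3ccncc3)n2)cc(OCCn2ccnc2)c1` gives 200 nM. Compound 4 `Oc1ccc(Nc2nccc(-c3ccncc3)n2)cc1` differs from compound 1 by hydroxy in place of hydrogen on an aromatic carbon, placed para to a large group. Within the data shown here, two measured steps bear on this change, each adding a group on an aromatic carbon of compound 1: a 3.0-fold higher number from compound 1 to compound 2 (0.48 log units; beyond the scatter), and a 4.5-fold lower number from compound 1 to compound 3 (0.65 log units; beyond the scatter). The two point in opposite directions, so the direction for a hydroxy group is uncertain and nothing larger than a modest step is expected. For compound 4 the expected step is a 1.5-fold lower number from compound 1 to compound 4 (0.18 log units; within the scatter). Compound 4 is estimated at 600 nM, with a range of 200 nM to 1800 nM.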

Compound 4, half-maximal inhibitory concentration: 3300 nM
Compound 4: the middle estimate sits 5.5-fold (0.74 log units) below what was measured, and the stated range ends below it.
By their numbers in this assay, from the lowest: compound 3; then compound 1; then compounds 2 and 4 (each within the scatter of the next).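

Hydroxy para to a large group raises the number in this assay (a 3.7-fold higher number from compound 1 to compound 4 (0.56 log units; beyond the scatter)), so this small addition of 1 heavy atom does not give the gain seen with the larger 2-(1H-imidazol-1-yl)ethoxy group (a 4.5-fold lower number from compound 1 to compound 3 (0.65 log units; beyond the scatter)). Its step runs in the same direction as that of acetamido (a 3.0-fold higher number from compound 1 to compound 2 (0.48 log units; beyond the scatter)). Nothing shown accounts for the rise.

From the compounds shown here alone, it remains open whether the rise belongs to hydroxy itself or to this place on the ring. A methoxy group or an amine at the same place would help separate the two.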